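One methyl removed from the weakest of three

This account rests on a few compounds, and the source may have more. Where it says the series, first, only, none or still open, it means among the compounds named here.

In a functional assay on PC-3 cells (Homo sapiens) for cytotoxicity, read by MTT assay, with a stated time of 48 h (a higher number here means a weaker inhibitor, a lower number a stronger inhibitor), compound 1 `COc1ccc(-c2nc(-c3c[nH]c4ccccc34)co2)cc1OC` gives 359000 nM, the highest of the three numbers recorded. Compound 3 `COc1ccc(-c2nc(-c3c[nH]c4ccccc34)co2)cc1` gives 133000 nM, and compound 2 `Fc1ccc(-c2nc(-c3c[nH]c4ccccc34)co2)cc1` gives 42800 nM. The step of a 2.7-fold lower number from compound 1 to compound 3 (0.43 log units; beyond the scatter) and the step of a 3.1-fold higher number from compound 2 to compound 3 (0.49 log units; beyond the scatter) show that swapping or removing a substituent here moves the number only modestly. Compound 4 `COc1cc(-c2nc(-c3c[nH]c4ccccc34)co2)ccc1O` differs from compound 1 by hydrogen in place of methyl on an oxygen on an aromatic ring. Going by the values given here, no measured pair covers this exact change; the step from compound 1 to compound 3 is the nearest, and it removed the whole methoxy rather than only its methyl. For compound 4 the expected step is a 1.4-fold lower number from compound 1 to compound 4 (0.16 log units; within the scatter), likely within or just beyond the scatter, direction uncertain. Compound 4 is estimated at 250000 nM, between 80000 nM and 800000 nM.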

Compound 4, half-maximal inhibitory concentration: 303000 nM
For compound 4 the middle estimate is 1.2-fold (0.08 log units) below the measured one; low and high end bracket the measured number.
By their numbers in this assay, from the lowest: compound 2; then compound 3; then compounds 4 and 1 (each within the scatter of the next).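

The step of a 1.2-fold lower number from compound 1 to compound 4 (0.07 log units; within the scatter) shows that on this oxygen, methoxy to hydroxy gives no change that can be told from the scatter. This differs from the step of a 2.7-fold lower number from compound 1 to compound 3 (0.43 log units; beyond the scatter), which removes the whole methoxy that compound 4 keeps, so the two steps concern different methoxy groups. Nothing available explains this result.

The compounds shown leave open whether a longer chain on this oxygen, or an amine in place of the hydroxy, would move the number. They also leave open whether hydroxy would behave the same without the remaining methoxy.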